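The compounds below may be only part of what the source reports. "The series", "measured", "known", "first", "only" and "open" are said of these compounds alone.

Three compounds share one core and differ only in the aromatic group attached to the carbon that carries a double bond to nitrogen. Compound 1, `CN(C)CCn1cnnc1-c1cc(Oc2ccc(NC(=O)N/N=C/c3c[nH]c4ccccc34)cc2F)ccn1`, carries a 1H-indol-3-yl there and in a functional assay on U-87MG ATCC cells (Homo sapiens) for cytotoxicity, read by MTT assay, with a stated time of 72 h (a lower number here means a stronger inhibitor, a higher number a weaker inhibitor), compound 1 gives 690 nM. Compound 2, `CN(C)CCn1cnnc1-c1cc(Oc2ccc(NC(=O)N/N=C/c3ccccc3O[N+](=O)[O-])cc2F)ccn1`, carries a 2-(nitrooxy)phenyl, and in this assay compound 2 gives 7150 nM; the change is a 10-fold higher number from compound 1 to compound 2 (1.02 log units; beyond the scatter). Compound 3, `CN(C)CCn1cnnc1-c1cc(Oc2ccc(NC(=O)N/N=C/c3cccc(O)c3)cc2F)ccn1`, carries a 3-hydroxyphenyl. As far as these compounds go, for compound 3 this assay reports only a limit, > 100000 nM, so it stands as the weakest of the three and its exact number is unknown. The step of an at least 140-fold higher number from compound 1 to compound 3 (2.16 log units; beyond the scatter) and the step of an at least 13-fold higher number from compound 2 to compound 3 (1.14 log units; beyond the scatter) both rest on that limit, (the limit of > 100000 nM in this assay, at which 1 of the 3 values shown sits).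

Compound 4, `Cc1cc(/C=N/NC(=O)Nc2ccc(Oc3ccnc(-c4nncn4CCN(C)C)c3)c(F)c2)cc(C)c1O`, is the next step: 4-hydroxy-3,5-dimethylphenyl in place of 3-hydroxyphenyl on a carbon with a double bond to nitrogen. It keeps a hydroxyphenyl on the same carbon, so the two steps that bear on it are those leading to compound 3, both large rises in the number. Starting from a limit, the direction of the step cannot be fixed with confidence; a modest drop in the number is expected, since compound 4 keeps the hydroxyphenyl that gave compound 3 its > 100000 nM. The expected step is an at least 1.6-fold lower number from compound 3 to compound 4 (0.22 log units; that floor lies within the scatter). Compound 4 is estimated at 60000 nM, within a range from 12000 nM to 300000 nM.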

Compound 4, half-maximal inhibitory concentration: 7710 nM
Beside the measured number, compound 4's estimate is 7.8-fold (0.89 log units) above it; measured number outside the range, below it.
By their numbers in this assay, from the lowest: compound 1; then compounds 2 and 4 (each within the scatter of the next). At a limit, above all of these: compound 3.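

Changing the group on this carbon to 4-hydroxy-3,5-dimethylphenyl gives an at least 12-fold lower number from compound 3 to compound 4 (1.11 log units; beyond the scatter) in this assay, so carrying a hydroxyphenyl here does not by itself mean the very weak result seen for compound 3. Other groups can now be compared with this one: a 1.1-fold higher number from compound 2 to compound 4 (0.03 log units; within the scatter), which leaves two quite different groups within the usual scatter of each other, while an 11-fold higher number from compound 1 to compound 4 (1.05 log units; beyond the scatter) shows that the 1H-indol-3-yl of compound 1 still gives the lowest number of the series. The true size of the first step remains unknown, since the value for compound 3 is only a limit and the printed step is a minimum: the limit of > 100000 nM in this assay, at which 1 of the 4 values shown sits.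

The new group differs from 3-hydroxyphenyl both in its two methyl groups and in where its hydroxyl sits, so the compounds shown leave open which of these changes matters, a question that a plain 4-hydroxyphenyl would help to settle. As far as these compounds go, it is also open whether a methoxy group in place of the hydroxyl, or an amine on the same ring, would hold the number at this level or move it towards that of compound 1.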